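Changing the Aryl Group on the Ring Nitrogen

The source may report more compounds than this note shows. Statements on the series, on what has been measured and on what is new or still open speak of the compounds shown alone.

Compound 1 `COc1cc(-c2ncnn2-c2ccccc2)cc(OC)c1OC`: in a functional assay on A549 cells (Homo sapiens) for antiproliferative activity, read by MTT assay, with a stated time of 72 h (on this read-out higher numbers stand for weaker inhibition and lower numbers for stronger inhibition), compound 1 gives > 10000 nM, which is a limit of the assay rather than a number.
Compound 2 `COc1ccc(-n2ncnc2-c2cc(OC)c(OC)c(OC)c2)cc1`: in this assay compound 2 gives > 10000 nM, again a limit.
Compound 3 `COc1cc(-c2ncnn2-c2ccc(Cl)c(Cl)c2)cc(OC)c1OC`: in this assay compound 3 gives > 10000 nM, also a limit.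

All three measured compounds therefore stand at the same place, (the limit of > 10000 nM in this assay, at which 3 of the 3 values shown sit), and compound 3 is no exception: its result is only a limit, and none of the three compounds can be ranked against the others.

The unmeasured compound 4 `COc1cc(-c2ncnn2-c2ccc(F)cc2)cc(OC)c1OC` differs from compound 3 in the group carried on the ring nitrogen: 4-fluorophenyl in place of 3,4-dichlorophenyl on an aromatic nitrogen.

Two of the measured steps concern this same position. The step that the two limits leave unreadable from compound 1 to compound 3 and the step that the two limits leave unreadable from compound 2 to compound 3 both swap the aryl group on the ring nitrogen, and both are unreadable, since each end sits at the limit. The third step, a step that the two limits leave unreadable from compound 1 to compound 2, is equally unreadable. Nothing measured here resolves a change at this position, so no step beyond the scatter can be anticipated in this assay, in either direction.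

Compound 4 is therefore expected to give about 20000 nM in this assay, within a range of 5000 nM to 80000 nM, an expected step that the limit leaves unreadable from compound 3 to compound 4, most likely reported again as a limit.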

Compound 4, half-maximal inhibitory concentration: > 10000 nM
Compound 4 ended at the assay's limit (the forecaster's own chance of this, stated with the estimate: 75%); the middle value does not contradict the limit.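

The steps from compound 1, compound 2 and compound 3 to compound 4 cannot be read, since all four results are only a limit: the limit of > 10000 nM in this assay, at which 4 of the 4 values shown sit.

The compounds shown leave open whether any aryl group on the ring nitrogen of the shared core gives a readable value in this assay, and how large a change at that position could be.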